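Fluoro in Place of Chloro on the Anilide Ring

A few compounds are considered here, and "the series" means these few. Any claim that something is new, unique, unknown or untested is made for them only; others in the source may bear on it.

Compound 1 `O=C(Nc1ccc(Cl)cc1)C1(c2ccc3c(n2)CCN3c2ccccn2)CCC1` is a cyclobutane carboxamide whose core carries a pyridin-2-yl group on the ring nitrogen and a 4-chlorophenyl amide. In an assay on HeLa cells for inhibition of Indoleamine 2,3-dioxygenase 1 (Homo sapiens) (a lower number here means a stronger inhibitor, a higher number a weaker inhibitor), compound 1 gives 2.3 nM, the second highest of three numbers. Its nearest neighbour is compound 2 `O=C(OC1CC1)N1CCc2nc(C3(C(=O)Nc4ccc(Cl)cc4)CCC3)ccc21`, which in this assay gives 2 nM; the step of a 1.2-fold lower number from compound 1 to compound 2 (0.06 log units; within the scatter) shows that swapping the pyridin-2-yl for a cyclopropyloxycarbonyl group leaves the number essentially unchanged. Compound 3 `COC(=O)N1c2ccc(C3(NC(=O)c4ccc(F)cc4)CC3)cc2[C@@H]2CC[C@@H]21`, with a different core and a reversed amide bearing a 4-fluorophenyl group, gives 5.6 nM in this assay.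

Compound 4 `O=C(Nc1ccc(F)cc1)C1(c2ccc3c(n2)CCN3c2ccccn2)CCC1` differs from compound 1 by fluoro in place of chloro on an aromatic carbon, on the aromatic carbon para to the amide nitrogen. No measured step bears directly on this change: the one step shown concerns the group on the ring nitrogen, and compound 3 carries its fluorophenyl on the other side of the amide, so its value only hints that a fluorophenyl amide can remain potent. Compound 4 is therefore expected to stay close to compound 1, with at most a small step of a 1.7-fold higher number from compound 1 to compound 4 (0.24 log units; within the scatter) toward a higher number. The estimate for compound 4 in this assay is 4 nM, within a range of 1.5 nM to 12 nM.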

Compound 4, half-maximal inhibitory concentration: 10.9 nM
Beside the measured number, compound 4's estimate is 2.7-fold (0.44 log units) below it; the range from low to high includes it.
By their numbers in this assay, from the lowest: compounds 2 and 1 (each within the scatter of the next); then compounds 3 and 4 (each within the scatter of the next).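

On the shared core of compound 1, the exchange of chloro for fluoro on the aromatic carbon para to a large group produces a clear change in this assay, with a 4.7-fold higher number from compound 1 to compound 4 (0.68 log units; beyond the scatter), whereas the earlier change on the ring nitrogen, a 1.2-fold lower number from compound 1 to compound 2 (0.06 log units; within the scatter), stayed within the scatter. This position on the 4-chlorophenyl ring therefore responds to the swap of one halogen for another, even though the exchange replaces one heavy atom with one heavy atom and, by the computed count, adds no hydrogen-bond donor, acceptor or net charge. Nothing in the data shown explains why fluoro gives the higher number here.

The compounds shown leave open whether the same exchange would produce a step of similar size on compound 2, which carries cyclopropyloxycarbonyl in place of pyridin-2-yl. They also leave open how a bromo, methyl, methoxy or nitrile group at this place would compare with chloro and fluoro, and so whether chloro is unusually favourable here or fluoro unusually poor.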